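Replacing a terminal phenyl with a pentenyl chain

The source may hold more compounds than are shown below. What is called first, only, known or untested is meant among the compounds shown, and "the series" means these compounds.

The compounds measured so far, with their values in an assay on HEK-293T cells for inhibition of diacylglycerol lipase-alpha (Homo sapiens), read by colorimetric assay; on this read-out lower numbers stand for stronger inhibition and higher numbers for weaker inhibition:

Compound 1, `O=C(CCCCCc1ccccc1)c1nc2ccc(F)cc2o1`: 708 nM
Compound 2, `O=C(CCCCCCc1ccccc1)c1nnc(-c2ccccc2)[nH]1`: > 10000 nM, which is a limit of the assay and not a number
Compound 3, `O=C(CCCCc1ccccc1)c1nc2ncccc2o1`: 204 nM

Among the numbers shown, compound 3 stands lowest. The nearest number is that of compound 1, which is higher and lies beyond the usual scatter. Compound 2 sits at the limit of > 10000 nM in this assay, at which 1 of the 3 values shown sits, so it contributes only a limit.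

Compound 4, `C=CCCCCCCCC(=O)c1nc2ncccc2o1`, has not yet been measured in this assay. It differs from compound 3 in one place: pent-4-en-1-yl in place of phenyl on a saturated chain carbon, four bonds along the chain from a carbonyl carbon. Within the data shown here, no two measured compounds differ by exactly this change, so there is no measured step to lean on. The chain of compound 4 is open and carries a double bond, where compound 3 carries a ring. In this assay the step from compound 3 to compound 4 is expected to be a 2.7-fold higher number from compound 3 to compound 4 (0.43 log units; beyond the scatter), a loss of moderate size, beyond the scatter but not large. Compound 4 is therefore estimated at 550 nM, with a range from 150 nM to 2500 nM.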

Compound 4, half-maximal inhibitory concentration: 550 nM
Compound 4: middle estimate and measured number agree at the digits printed, and the stated range covers the measured number.
By their numbers in this assay, from the lowest: compound 3; then compounds 4 and 1 (each within the scatter of the next). At a limit, above all of these: compound 2.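

In this assay the terminal phenyl turns out not to be required for a measurable number: pent-4-en-1-yl in its place, on a saturated chain carbon, four bonds along the chain from a carbonyl carbon, gives a 2.7-fold higher number from compound 3 to compound 4 (0.43 log units; beyond the scatter) and thus a modest loss. Among these compounds, this is the first measured change at this position, and compound 4 at 550 nM still gives a measurable number, so an open chain with a double bond is tolerated here, though the phenyl gives the lower number. Nothing measured here gives a reason for this step.

As far as these compounds go, it remains open whether a saturated pentyl chain or a terminal cyclohexyl would give a number nearer to that of the phenyl or of the pent-4-en-1-yl. From the compounds shown here alone, it also remains open whether the same change would cost as much on the core of compound 1.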